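Swapping the Aryl Ketone in a Trimethoxyphenyl Series

The source may report more compounds than this note shows. Statements on the series, on what has been measured and on what is new or still open speak of the compounds shown alone.

Three compounds sharing one core have been examined in a functional assay on PC-3 cells (Homo sapiens) for cytotoxicity, read by MTT assay, with a stated time of 48 h; on this read-out higher numbers stand for weaker inhibition and lower numbers for stronger inhibition. Compound 1 `COc1cc(-c2nnc3n2NC(c2cccs2)C(C(=O)c2ccccc2)S3)cc(OC)c1OC` gives 86300 nM, and compound 3 `COc1ccc(C(=O)C2Sc3nnc(-c4cc(OC)c(OC)c(OC)c4)n3NC2c2cccs2)cc1` gives 95900 nM; the step from one to the other, a 1.1-fold higher number from compound 1 to compound 3 (0.05 log units; within the scatter), shows that methoxy in place of hydrogen on an aromatic carbon of the ketone ring left the number essentially unchanged. Compound 2 `COc1cc(-c2nnc3n2NC(c2ccco2)C(C(=O)c2ccc(C)cc2)S3)cc(OC)c1OC`, which carries furan in place of thiophene and a 4-methylphenyl ketone, gives 7500 nM, the lowest number of the three, its gaps to both compound 1 and compound 3 lying beyond the scatter.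

Compound 4 `COc1cccc(C(=O)C2Sc3nnc(-c4cc(OC)c(OC)c(OC)c4)n3NC2c2ccco2)c1` differs from compound 2 by one change: 3-methoxyphenyl in place of 4-methylphenyl on a carbonyl carbon. Among the compounds with values here, the only measured step that bears on it is the methoxy addition from compound 1 to compound 3, which was within the scatter, so little guidance exists on whether moving from 4-methylphenyl to 3-methoxyphenyl matters. Given that compound 2 stands apart from the other two, a modest drift toward higher numbers is estimated, a 2.0-fold higher number from compound 2 to compound 4 (0.30 log units; within the scatter). Compound 4 is therefore expected to give about 15000 nM in this assay, with a range from 5000 nM to 50000 nM.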

Compound 4, half-maximal inhibitory concentration: 84600 nM
Beside the measured number, compound 4's estimate is 5.6-fold (0.75 log units) below it; measured number outside the range, above it.
By their numbers in this assay, from the lowest: compound 2; then compounds 4, 1 and 3 (each within the scatter of the next).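

The ketone aryl group is not a silent position in this series. In this assay, with furan held in place, 3-methoxyphenyl in place of 4-methylphenyl on the carbonyl carbon gives an 11-fold higher number from compound 2 to compound 4 (1.05 log units; beyond the scatter) and so removes most of what set compound 2 apart. The earlier methoxy step, a 1.1-fold higher number from compound 1 to compound 3 (0.05 log units; within the scatter) on the thiophene side, gave no sign of a change of this size, so that flat result does not extend to this exchange, and nothing at hand accounts for the gap.

The compounds shown leave open whether the gap belongs to the 4-methylphenyl group or to the 3-methoxyphenyl group, and whether it would recur with thiophene in place of furan. Going by these compounds, how a chlorine atom or an amine on the ketone ring would read also remains open.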